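Swapping Trifluoromethoxy for Methyl: An Expected Small Step

This account rests on a few compounds, and the source may have more. Where it says the series, first, only, none or still open, it means among the compounds named here.

Measured compounds:
Compound 1 `Cc1ccc(C2=Nn3c(nnc3C(C)c3ccc(CC(C)C)cc3)SC2)cc1` gives 6300 nM in a functional assay on MCF7 cells (Homo sapiens) for inhibition, read by sulforhodamine B assay, with a stated time of 72 h; a higher number here means a weaker inhibitor, a lower number a stronger inhibitor.
Compound 2 `COc1ccc2cc(C(C)c3nnc4n3N=C(c3ccc(OC(F)(F)F)cc3)CS4)ccc2c1` gives 8800 nM in this assay.
Compound 3 `COc1ccc(C2=Nn3c(nnc3C(C)c3ccc(-c4ccccc4)c(F)c3)SC2)cc1` gives 2600 nM in this assay.

Among these three, compound 2 has the highest number. Its gap to compound 1 is within the scatter of repeated measurements, so the two cannot be told apart on the numbers; its gap to compound 3 lies beyond the scatter, so compound 3 is the more potent of that pair. The three compounds differ from one another in more than one place, so none of these gaps can be pinned to a single structural feature.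

The unmeasured compound 4 `COc1ccc2cc(C(C)c3nnc4n3N=C(c3ccc(C)cc3)CS4)ccc2c1` differs from compound 2 in one place: methyl in place of trifluoromethoxy on an aromatic carbon. A methyl in place of trifluoromethoxy on an aromatic carbon, para to a large group, is a modest change in size. Among the compounds with values here, no pair of measured compounds isolates this exact change, so there is no measured step to lean on. A step of no more than the usual scatter is expected, with a slight lean toward a lower number; the expected step is a 1.3-fold lower number from compound 2 to compound 4 (0.10 log units; within the scatter). On that basis compound 4 is expected to give 7000 nM in this assay, within a range from 2500 nM to 20000 nM.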

Compound 4, half-maximal inhibitory concentration: 11000 nM
Compound 4: the middle estimate sits 1.6-fold (0.20 log units) below what was measured; measured number inside the range.
By their numbers in this assay, from the lowest: compound 3; then compounds 1, 2 and 4 (each within the scatter of the next).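

In this assay, moving from 4-(trifluoromethoxy)phenyl to 4-methylphenyl gives a 1.3-fold higher number from compound 2 to compound 4 (0.10 log units; within the scatter), so the two compounds cannot be told apart on their numbers. Within the data shown here, this is the first pair here that differs in only one place, and it gives the earlier gaps something they could not: a reading tied to a single structural change. On an aromatic carbon, para to a large group, a group of 5 heavy atoms with 1 hydrogen-bond acceptor and a group of 1 heavy atom with none give results that cannot be separated, and no measurement shown here bears on what lies behind that result.

Only these two groups are shown at this position, so it remains open whether an amine, a carboxylic acid or a longer chain there would also leave the number within the scatter. As far as these compounds go, it is also open whether the same swap would give so small a step when the rest of the molecule differs, as it does in compound 1 and compound 3.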